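Series notes: extending the vinyl arm of compound 1

This account rests on a few compounds, and the source may have more. Where it says the series, first, only, none or still open, it means among the compounds named here.

Compound 1, `C=C[C@@](C)(/C=C/c1ccc(O)c(/C=C/C#N)c1)CCC=C(C)C`, is the reference point of the series. In a functional assay on SEM cells (Homo sapiens) for cytotoxicity, with a stated time of 72 h (a lower number here means that less compound is needed, a higher number that more compound is needed for the effect), compound 1 gives only a limit, > 36600 nM. Compound 2, `C=C[C@@](C)(/C=C/c1ccc(O)c(/C=C/C(=O)O)c1)CCC=C(C)C`, carries carboxy in place of cyano on a double-bonded chain carbon bound to a double-bonded chain carbon. In this assay compound 2 likewise returns a limit, > 36600 nM. The step that the two limits leave unreadable from compound 1 to compound 2 therefore cannot be read, and the limit of > 36600 nM in this assay, at which 2 of the 2 values shown sit, sums up the record so far: neither measured compound yields a number, so compound 1 stands nowhere on a scale, only at a limit.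

Compound 3, `COc1ccc(/C=C/[C@@](C)(/C=C/c2ccc(O)c(/C=C/C#N)c2)CCC=C(C)C)cc1`, is the compound awaiting measurement; its change from compound 1 is 2-(4-methoxyphenyl)ethenyl in place of vinyl on a saturated chain carbon bound to a double-bonded chain carbon and two saturated chain carbons. Among the compounds with values here, no measured step touches this place on the saturated chain carbon, so the one recorded step bears on it only in that both of its endpoints are limits. The expected step of an at least 1.2-fold lower number from compound 1 to compound 3 (0.08 log units; that floor lies within the scatter) is accordingly set at none beyond the scatter, anchored on compound 1 at its limit of > 36600 nM. Compound 3 is expected at 30000 nM, within 8000 nM to 100000 nM, with a fair chance that this assay again reports only a limit.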

Compound 3, half-maximal effective concentration: 4540 nM
Compound 3: the middle estimate sits 6.6-fold (0.82 log units) above what was measured; measured number outside the range, below it.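

At the saturated chain carbon bound to a double-bonded chain carbon and two saturated chain carbons, 2-(4-methoxyphenyl)ethenyl in place of vinyl gives an at least 8.0-fold lower number from compound 1 to compound 3 (0.90 log units; beyond the scatter) in this assay, the first sign that the series responds to a change at this place. Compound 1 is a limit, so this step has a floor but no upper end, and the real size may be larger. Compound 3 is the only compound shown with a number, which gives the series a measurable reference point, while the step from compound 1 to compound 2 cannot be read and the remaining record stays at a limit: the limit of > 36600 nM in this assay, at which 2 of the 3 values shown sit.

Still open, as far as these compounds go, is whether the gain belongs to the added aromatic ring, to its methoxy group or simply to the longer arm, a question that a plain 2-phenylethenyl arm, or an amine in place of the methoxy group, would help to settle. Also open is whether the gain in this assay reflects a selective effect on SEM cells, as no other cell line is shown for any of these compounds.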